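The source may report more compounds than this note shows. Statements on the series, on what has been measured and on what is new or still open speak of the compounds shown alone.

For the measured compounds named here, compound 2 `CC(C)C[C@H](N)c1cc(C(F)(F)F)ccc1N1CCN(C(=O)CCc2cccc(C(F)(F)F)c2)CC1` is one of two compounds measured so far in an assay on HEK293 cells for displacement of a labelled ligand from Melanocortin receptor 4 (Homo sapiens) (a higher number here means a weaker inhibitor, a lower number a stronger inhibitor), where compound 2 gives 2200 nM. Going by the values given here, its only measured neighbour is compound 1 `Cc1cccc(CCC(=O)N2CCN(c3ccc(C(F)(F)F)cc3[C@@H](N)CC(C)C)CC2)c1`, which gives 2100 nM in this assay, and the step of a 1.0-fold higher number from compound 1 to compound 2 (0.02 log units; within the scatter) is within the scatter, so the two numbers cannot be told apart. Compound 3 `COc1cccc(CCC(=O)N2CCN(c3ccc(C(F)(F)F)cc3[C@@H](N)CC(C)C)CC2)c1` alters the same aromatic carbon once more: methoxy in place of trifluoromethyl on an aromatic carbon. Among the compounds with values here, the single step that bears on this position was flat, so a step of about a 1.1-fold lower number from compound 2 to compound 3 (0.04 log units; within the scatter) is expected, nothing beyond the scatter. Compound 3 is therefore estimated at 2000 nM, with a range from 700 nM to 6000 nM.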

Compound 3, inhibition constant: 4000 nM
Compound 3: the middle estimate sits 2.0-fold (0.30 log units) below what was measured; the range from low to high includes it.
By their numbers in this assay, from the lowest: compounds 1, 2 and 3 (each within the scatter of the next).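

Methoxy, which brings an oxygen and a hydrogen-bond acceptor, now joins methyl and trifluoromethyl on this aromatic carbon, and this assay still does not separate them, with a 1.8-fold higher number from compound 2 to compound 3 (0.26 log units; within the scatter) and a 1.9-fold higher number from compound 1 to compound 3 (0.28 log units; within the scatter). So far, three different groups at this place give values that cannot be told apart. No measurement shown explains this result. As far as these compounds go, it remains open whether an amine, a carboxylic acid or a longer chain on this carbon would move the number beyond the scatter.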